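The source may hold more compounds than are shown below. What is called first, only, known or untested is meant among the compounds shown, and "the series" means these compounds.

Measured so far:
Compound 1, `CC(=O)c1ccc(-c2ccc3c(O)cccc3c2)cc1`: in an assay for binding affinity to 17-beta-hydroxysteroid dehydrogenase type 1 (Homo sapiens), with a stated time of 20 min, tested at 1 uM (a lower number here means less inhibition, a higher number more inhibition at the concentration tested (going by the name of the read-out)), compound 1 gives 16%.
Compound 2, `CC(=O)Nc1cccc(-c2ccc(CO)cc2)c1`: in this assay compound 2 gives < 10%, which is a limit of the assay and not a number.

Compound 2 thus stands at the lower edge of what has been measured here: the limit of < 10% in this assay, at which 1 of the 2 values shown sits. Compound 1 returns a number, compound 2 only the limit, and nothing more can be read from these two values together, since no single-point change connects them.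

The unmeasured compound 3, `O=C(Nc1cccc(-c2ccc(CO)cc2)c1)c1ccccc1`, differs from compound 2 in one place: phenyl in place of methyl on a carbonyl carbon. For the measured compounds named here, no measured pair covers this change, so any expectation rests on the structures alone. A step in this assay of a modest size, towards somewhat more inhibition, is expected, though it may well stay within the scatter. Compound 3 is therefore estimated at 14%, with a range from 0% to 32%. The expected step is a number at least 4 percentage points higher from compound 2 to compound 3 (that floor lies within the scatter).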

Compound 3, a percentage reported as inhibition, at one concentration (the size of the read-out at that concentration, not a potency): < 10%
Compound 3: no number, only a limit (the forecaster's own chance of this, stated with the estimate: 45%); middle value at least 4 percentage points away from the limit.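

In this assay compound 3 gives < 10%, which is a limit of the assay and not a number. No step can be read from compound 2 to compound 3, since both rest on one limit: the limit of < 10% in this assay, at which 2 of the 3 values shown sit. The compounds shown leave open whether phenyl in place of methyl on a carbonyl carbon changes inhibition at all.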